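A Second Chloro on the Urea-Bound Phenyl Ring

The compounds below may be only part of what the source reports. "The series", "measured", "known", "first", "only" and "open" are said of these compounds alone.

Measured compounds:
compound 1 `CCN(CC)CCCNc1nc(-c2ccc(NC(=O)Nc3ccccc3)cc2)nc2c(Cl)c(Cl)sc12` gives 1780 nM
compound 2 `CCN(CC)CCCNc1nc(-c2ccc(NC(=O)Nc3ccc(Cl)cc3)cc2)nc2c(Cl)c(Cl)sc12` gives 660 nM
compound 3 `CCN(CC)CCCNc1nc(-c2ccc(NC(=O)Nc3ccccc3Cl)cc2)nc2c(Cl)c(Cl)sc12` gives 970 nM

In a functional assay on MDA-MB-231 cells (Homo sapiens) for cytotoxicity, read by MTT assay, with a stated time of 72 h (on this read-out lower numbers stand for stronger inhibition and higher numbers for weaker inhibition), compound 3 gives the second highest of the three numbers. The steps of a 1.8-fold lower number from compound 1 to compound 3 (0.26 log units; within the scatter) and a 1.5-fold higher number from compound 2 to compound 3 (0.17 log units; within the scatter) both lie within the scatter, so compound 3 cannot be separated from its neighbours on these numbers alone.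

Compound 4 `CCN(CC)CCCNc1nc(-c2ccc(NC(=O)Nc3ccc(Cl)cc3Cl)cc2)nc2c(Cl)c(Cl)sc12` differs from compound 3 by chloro in place of hydrogen on an aromatic carbon. The step that bears on this change is a 2.7-fold lower number from compound 1 to compound 2 (0.43 log units; beyond the scatter), the same chloro entering the same ring on a parent that lacks it; that step was modest yet beyond the scatter. A step of similar size is therefore expected here, namely a 2.2-fold lower number from compound 3 to compound 4 (0.33 log units; beyond the scatter). On that basis compound 4 is estimated at 450 nM, with a range from 180 nM to 1100 nM.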

Compound 4, half-maximal inhibitory concentration: 3940 nM
Compound 4: middle estimate off by 8.8-fold (0.94 log units), on the low side; measured number outside the range, above it.
By their numbers in this assay, from the lowest: compounds 2, 3 and 1 (each within the scatter of the next, the first and the last beyond it); then compound 4.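

On the 2-chlorophenyl ring this chloro gives a 4.1-fold higher number from compound 3 to compound 4 (0.61 log units; beyond the scatter) and so reverses the direction seen on the unsubstituted phenyl ring: the same change on two cores in this assay, a 2.7-fold lower number (0.43 log units; beyond the scatter) from compound 1 to compound 2 and a 4.1-fold higher number (0.61 log units; beyond the scatter) from compound 3 to compound 4, 11-fold (1.04 log units) apart, beyond the scatter of two such steps. Adding a chloro at the other place, on the 4-chlorophenyl ring, gives a 6.0-fold higher number from compound 2 to compound 4 (0.78 log units; beyond the scatter) and the two chloro groups together give a 2.2-fold higher number from compound 1 to compound 4 (0.35 log units; beyond the scatter) even though each alone gives no higher number than the bare phenyl. Their effects therefore do not add up across these compounds: the same change on two cores in this assay, a 1.8-fold lower number (0.26 log units; within the scatter) from compound 1 to compound 3 and a 6.0-fold higher number (0.78 log units; beyond the scatter) from compound 2 to compound 4, 11-fold (1.04 log units) apart, beyond the scatter of two such steps.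

The compounds shown leave open why the second chloro raises the number. They also leave open whether a fluoro or methoxy group in its place would do the same.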